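The compounds below may be only part of what the source reports. "The series", "measured", "known", "first", "only" and "open" are said of these compounds alone.

Compounds measured in a functional assay on the whole organism (strain Wister albino) for inhibition, with Rattus norvegicus as the target, read by paw edema, with stated times of 1 h and 3 h, at a dose of 50 mg/kg by the intraperitoneal route (on this read-out lower numbers stand for less inhibition and higher numbers for more inhibition at the one dose given (going by the name of the read-out)), so far:

- compound 1, `CN1C(=O)[C@@]2(c3ccccc31)N(C)C[C@@H](c1ccco1)[C@@]21Cc2ccccc2C1=O`, gives 17.5%
- compound 2, `CN1C(=O)[C@@]2(c3ccccc31)N(C)C[C@@H](c1ccc(Cl)cc1)[C@@]21Cc2ccccc2C1=O`, gives 9.4%

Of the compounds shown here, two sharing one core have been tested. They differ only at a saturated ring carbon, where compound 1 carries furan-2-yl and compound 2 carries 4-chlorophenyl, and the read-out moves a number 8.1 percentage points lower from compound 1 to compound 2 (within the scatter). For the measured compounds named here, compound 2 therefore stands at the lower of the two numbers, with compound 1 as its only neighbour, but the gap between them is too small to call a real difference.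

Compound 3, `Cc1ccc([C@@H]2CN(C)[C@]3(C(=O)N(C)c4ccccc43)[C@]23Cc2ccccc2C3=O)cc1`, is the next compound, not yet measured. It differs from compound 2 by methyl in place of chloro on an aromatic carbon.

Going by the values given here, no measured step changes a substituent on that aromatic ring, so nothing bears directly on this exchange. Among the compounds with values here, the one step known is small, and the two compounds sit close together at low inhibition. A small shift, in either direction, is the most reasonable expectation: compound 3 is expected to lie a number 2.6 percentage points higher from compound 2 to compound 3 (within the scatter) from compound 2. The estimate for compound 3 in this assay is 12%, expected to fall between 2% and 24%.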

Compound 3, a percentage reported as inhibition, in the whole organism at one dose (the size of the read-out at that dose, not a potency): 6.4%
For compound 3 the middle estimate is 5.6 percentage points above the measured one; the measured number falls inside the stated range.
By their numbers in this assay, from the lowest: compounds 3, 2 and 1 (each within the scatter of the next, the first and the last beyond it).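

In this assay, putting methyl in place of chloro on an aromatic carbon, para to a large group, gives a number 3 percentage points lower from compound 2 to compound 3 (within the scatter), so this first change on that ring, one heavy atom for another, cannot be told apart from no change at all. At the saturated ring carbon, 4-methylphenyl in place of furan-2-yl gives a number 11.1 percentage points lower from compound 1 to compound 3 (beyond the scatter), a modest step, but the first in this short series to pass beyond the usual scatter. Compound 2 goes against any simple rule that a substituted phenyl at this carbon separates from furan-2-yl, since its step from compound 1 stays within the scatter, so the separation holds for compound 3 alone.

On these data alone, an amine, a carboxylic acid or a longer chain such as butyl on that aromatic carbon remains open, as does an unsubstituted phenyl at the saturated ring carbon, so it is unknown whether anything at either place lifts the read-out well clear of these three compounds. No separate measurement bears on why either step has the size it has.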